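Formyl for hydroxymethyl in a series held at its limit

The source may hold more compounds than are shown below. What is called first, only, known or untested is meant among the compounds shown, and "the series" means these compounds.

In a functional assay on Raji cells (Homo sapiens) for cytotoxicity, with a stated time of 72 h (on this read-out lower numbers stand for an effect already at smaller amounts and higher numbers for an effect only at larger amounts of compound), compound 1 (`C=C[C@@](C)(/C=C/c1ccc(OS(=O)(=O)c2ccc(C)cc2)cc1)CCC=C(C)C`) reads > 26000 nM as a limit of the assay and not a number. Compound 2 (`C=C[C@@](C)(/C=C/c1ccc(O)cc1)CC/C=C(C)/C=C/C(=O)OCc1ccccc1`) reads > 26000 nM as a limit too. Compound 3 (`C=C[C@@](C)(/C=C/c1ccc(O)c(CO)c1)CCC=C(C)C`) also reads > 26000 nM as a limit. The whole measured picture is therefore the limit of > 26000 nM in this assay, at which 3 of the 3 values shown sit, and compound 3 has no number of its own. Within the data shown here, no measured step connects any pair, so the series offers no size of change to borrow.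

The change from compound 3 to compound 4 (`C=C[C@@](C)(/C=C/c1ccc(O)c(C=O)c1)CCC=C(C)C`) is formyl in place of hydroxymethyl on an aromatic carbon, ortho to a hydroxy group and meta to a large group (formyl in place of hydroxymethyl on an aromatic carbon) with the shared core otherwise the same.

A move toward lower numbers in this assay is expected, modest in size and possibly no larger than the usual scatter, and a further reading at the limit would be no surprise. This expectation starts from compound 3 at > 26000 nM as a limit, so it is loosely anchored. The estimated step is an at least 1.4-fold lower number from compound 3 to compound 4 (0.15 log units; that floor lies within the scatter) and it remains only an expectation. In this assay the expected value for compound 4 is 18000 nM with an estimated range from 5000 nM to 40000 nM as a working guess.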

Compound 4, half-maximal effective concentration: > 26000 nM
Compound 4 gave a limit, no number; the forecaster's own chance of this, stated with the estimate: 55%; at least 1.4-fold (0.15 log units) between middle value and limit.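

Compound 3 and compound 4 both stand at a limit in this assay, not at a number, so no step can be read between them. The compounds shown leave open whether formyl in place of hydroxymethyl shifts this read-out at all, and how any of them would rank, with the whole series at one value: the limit of > 26000 nM in this assay, at which 4 of the 4 values shown sit.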